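The compounds below may be only part of what the source reports. "The series", "measured", "known", "first", "only" and "open" are said of these compounds alone.

Compound 1 `COc1cc(C2CC(c3cc4ccccc4o3)=NN2C(=O)Nc2ccccc2O)ccc1O` gives 22000000 nM in a functional assay on microsomes from liver (Rattus norvegicus, strain Wistar) for inhibition, with a stated time of 15 min; on this read-out lower numbers stand for stronger inhibition and higher numbers for weaker inhibition
Compound 2 `COc1cc(NC(=O)N2N=C(c3cc4ccccc4o3)CC2c2ccc(O)c(OC)c2)ccc1O` gives 12000000 nM in this assay

Only these two numbers exist so far, and they do not separate compound 2 from compound 1. The measured change is a 1.8-fold lower number from compound 1 to compound 2 (0.26 log units; within the scatter) and it puts 4-hydroxy-3-methoxyphenyl in place of 2-hydroxyphenyl on an amide-type nitrogen. Compound 3 `COc1cc(C2CC(c3cc4ccccc4o3)=NN2C(=O)Nc2ccc(O)c(O)c2)ccc1O` differs from compound 2 by hydrogen in place of methyl on an oxygen on an aromatic ring and nothing else: hydrogen in place of methyl on an oxygen on an aromatic ring, turning 4-hydroxy-3-methoxyphenyl into 3,4-dihydroxyphenyl. Going by the values given here, no measured pair shows this exact change. Among the compounds with values here, the one step that bears on it alters the same group, and at a 1.8-fold lower number from compound 1 to compound 2 (0.26 log units; within the scatter) it stayed small, so no step beyond the scatter is expected, in either direction. The estimated change is a 1.1-fold lower number from compound 2 to compound 3 (0.04 log units; within the scatter) in this picture. For compound 3 the expected value is 11000000 nM with an estimated range from 4000000 nM to 30000000 nM as its likely span.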

Compound 3, half-maximal inhibitory concentration: 11000000 nM
The estimate for compound 3 equals the measured number at the digits printed; the measured number falls inside the stated range.
By their numbers in this assay, from the lowest: compounds 3, 2 and 1 (each within the scatter of the next).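

In this assay, going by these compounds alone, hydrogen in place of methyl on this oxygen gives a 1.1-fold lower number from compound 2 to compound 3 (0.04 log units; within the scatter), so losing the methyl produces no step that this read-out can separate. The wider swap of 3,4-dihydroxyphenyl for 2-hydroxyphenyl on the amide-type nitrogen gives a 2.0-fold lower number from compound 1 to compound 3 (0.30 log units; within the scatter), which is also within the scatter, so the three hydroxy-bearing phenyl groups shown on this nitrogen cannot be told apart. No supporting data offer an explanation for how closely these numbers sit.

Going by these compounds, all three compounds carry a hydroxy-bearing phenyl group here, so it remains open whether a phenyl ring with a carboxylic acid or an amine, or a longer alkyl chain in place of the ring, would give a different number. On these data alone, the methoxy and hydroxy groups on the shared core are also identical throughout, so their contribution remains unknown.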